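Ring or chain on the alkyne: clearance of a third analogue

The source may hold more compounds than are shown below. What is called first, only, known or untested is meant among the compounds shown, and "the series" means these compounds.

Measured so far:
Compound 1 `NC(=O)c1cc(Cl)c2c(Cl)c(C#CC3CCOCC3)n([C@H]3CCCNC3)c2n1`: 102 mL/min/kg
Compound 2 `COCCC#Cc1c(Cl)c2c(Cl)cc(C(N)=O)nc2n1[C@H]1CCCNC1`: 113 mL/min/kg

Both values come from an ADME assay on the whole organism (Rattus norvegicus) for pharmacokinetics, at a dose of 3 mg/kg by the intravenous route; a lower number here means slower removal, a higher number faster removal of the compound. Compound 2 gives the higher of the two numbers, but a 1.1-fold higher number from compound 1 to compound 2 (0.04 log units; within the scatter), so the two compounds cannot be told apart here. Compound 3 `NC(=O)c1cc(Cl)c2c(Cl)c(C#CC3CCCO3)n([C@H]3CCCNC3)c2n1` carries oxolan-2-yl in place of 2-methoxyethyl on a triple-bonded carbon. For the measured compounds named here, the only step measured so far on this position, from a ring to a chain, was a 1.1-fold higher number from compound 1 to compound 2 (0.04 log units; within the scatter); a change back to a ring at the same position is therefore expected to move the number little. For compound 3 the expected step is a 1.1-fold lower number from compound 2 to compound 3 (0.03 log units; within the scatter), giving an estimate of 105 mL/min/kg with a range from 60 mL/min/kg to 180 mL/min/kg.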

Compound 3, clearance: 150 mL/min/kg
Beside the measured number, compound 3's estimate is 1.4-fold (0.15 log units) below it; low and high end bracket the measured number.
By their numbers in this assay, from the lowest: compounds 1, 2 and 3 (each within the scatter of the next).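

Oxolan-2-yl gives a third group on the triple-bonded carbon, and this assay still does not separate it from the others: the step to the chain is a 1.3-fold higher number from compound 2 to compound 3 (0.12 log units; within the scatter) and the step between the two rings is a 1.5-fold higher number from compound 1 to compound 3 (0.17 log units; within the scatter). Across these three compounds, neither ring size nor ring versus chain gives a step beyond the scatter. No measured evidence is available to explain this result. Still open, from the compounds shown here alone, is whether an amine or a carboxylic acid at this position would give a step beyond the scatter.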